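The source may report more compounds than this note shows. Statements on the series, on what has been measured and on what is new or still open speak of the compounds shown alone.

Measured in a functional assay on A549 cells (Homo sapiens) for cytotoxicity, read by MTT assay, with a stated time of 72 h; on this read-out lower numbers stand for an effect already at smaller amounts and higher numbers for an effect only at larger amounts of compound:
Compound 1 `O=c1cc(NC2CCCCC2)cc(/C=C/c2ccccc2)o1`: 1.25 uM
Compound 2 `COc1ccc(Nc2cc(C3CCCCC3)oc(=O)c2)cc1`: 4.62 uM
Compound 3 `COc1ccc(Nc2cc(-c3ccc4ccccc4c3)oc(=O)c2)cc1`: 0.15 uM

Compound 2, at 4.62 uM, has the highest number of the three, so it needs the largest amount to act on these cells. Compound 1 and compound 3 both lie lower, and both gaps are beyond the scatter.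

Compound 4 `COc1ccc(Nc2cc(-c3ccccc3)oc(=O)c2)cc1` is still unmeasured. It differs from compound 2 in one place, with phenyl in place of cyclohexyl on an aromatic carbon. Going by the values given here, no measured pair isolates this kind of change. Compound 1 differs from compound 2 in more than one place, so it gives no direct guide. The closest hint is compound 3, which also has an aromatic group at this place and gives 0.15 uM. A single phenyl is smaller than that group, so compound 4 is expected to fall between these two values, though this rests on very few compounds. In this assay a clear move towards a lower number is expected, an estimated 4.6-fold lower number from compound 2 to compound 4 (0.66 log units; beyond the scatter). The estimated value for compound 4 is 1 uM, with a range of 0.25 uM to 4 uM.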

Compound 4, concentration for half-maximal effect: 0.093 uM
The estimate for compound 4 lay 11-fold (1.03 log units) above the measured number, and the stated range ends above it.
By their numbers in this assay, from the lowest: compounds 4 and 3 (each within the scatter of the next); then compound 1; then compound 2.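

In this assay, replacing cyclohexyl with phenyl on this aromatic carbon, next to the ring oxygen, gives a large step, a 50-fold lower number from compound 2 to compound 4 (1.70 log units; beyond the scatter), although the heavy-atom count, donors, acceptors and charge all stay the same. Going by these compounds alone, this pair isolates the change from a non-aromatic to an aromatic ring at this position, which the earlier compounds could not do, and shows that this difference alone is enough to shift the number strongly. Nothing available here explains why.

Going by these compounds, it remains open how a pyridyl ring, which brings a ring nitrogen, or an open chain such as n-butyl would behave at this position. Also open, on these data alone, is whether a phenyl carrying a hydroxyl or an amine would keep the number as low as in compound 4.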